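Swapping methyl for fluoro on a pendant phenyl ring

This account rests on a few compounds, and the source may have more. Where it says the series, first, only, none or still open, it means among the compounds named here.

Measured compounds:
Compound 1, `Cc1ccc(-c2ccc(F)cc2)n1-c1ccc(-c2nc3ccc(F)cc3s2)cc1`: 3030 nM
Compound 2, `COc1ccc2nc(-c3ccc(-n4c(C)ccc4-c4ccc(C)cc4)cc3)sc2c1`: 4010 nM

Both compounds were tested in a functional assay on MDA-MB-231 cells (Homo sapiens) for cytotoxicity, read by sulforhodamine B assay, with a stated time of 48 h; a higher number here means a weaker inhibitor of growth, a lower number a stronger inhibitor of growth. Compound 1 gives 3030 nM in this assay, while compound 2 gives 4010 nM. Compound 2 shows the highest of the two numbers, but its nearest neighbour, compound 1, differs from it by only a small amount that lies within the usual scatter of repeated measurements, so the two compounds cannot be told apart on these data.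

The next compound, compound 3, has the structure `COc1ccc2nc(-c3ccc(-n4c(C)ccc4-c4ccc(F)cc4)cc3)sc2c1`. It differs from compound 2 by a single change: fluoro in place of methyl on an aromatic carbon. The 4-fluorophenyl group that results is also present in compound 1, but compound 1 differs from compound 3 in a second place as well, so no clean comparison exists between them.

For the measured compounds named here, with no measured step of this kind available, the change is expected to move the number little, if at all, beyond the scatter. Compound 3 is therefore expected to give 3500 nM in this assay, within a range from 1500 nM to 8000 nM. This estimate means a step of a 1.1-fold lower number from compound 2 to compound 3 (0.06 log units; within the scatter) that stays within the scatter.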

Compound 3, concentration for 50% growth inhibition: 4060 nM
Estimate against measurement, compound 3: 1.2-fold (0.06 log units) below; measured number inside the range.
By their numbers in this assay, from the lowest: compounds 1, 2 and 3 (each within the scatter of the next).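

In this assay, the step of a 1.0-fold higher number from compound 2 to compound 3 (0.01 log units; within the scatter) shows that 4-methylphenyl and 4-fluorophenyl cannot be told apart at this place, para to a large group, so this exchange leaves the read-out within the scatter on the core of compound 2. With the 4-fluorophenyl group now held constant, a second single change can also be read: a 1.3-fold higher number from compound 1 to compound 3 (0.13 log units; within the scatter), so methoxy and fluoro on an aromatic carbon of the shared core cannot be told apart either. Nothing available explains why neither exchange separates the compounds.

Methyl and fluoro each bring a single heavy atom, so these compounds do not show whether the para place tolerates larger or very different groups, such as an amine, a carboxylic acid or a longer chain. From the compounds shown here alone, with all three numbers within the scatter of each other, it also remains open which groups at either place, if any, would move the number in this assay beyond that scatter.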